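This account rests on a few compounds, and the source may have more. Where it says the series, first, only, none or still open, it means among the compounds named here.

Three compounds on the shared core have numbers in an ADME assay on microsomes from liver (Homo sapiens) for metabolic stability; a lower number here means slower removal, a higher number faster removal of the compound. Compound 1 `CCOc1nc(Nc2ccc(C(=O)NCC(C)(C)O)cc2OC)nc2[nH]ccc12` gives 0.8 mL.min-1.g-1, compound 2 `CCOc1nc(Nc2ccc(C(=O)N3C[C@@H](C)O[C@@H](C)C3)cc2OC)nc2[nH]ccc12` gives 1.5 mL.min-1.g-1 and compound 3 `CCOc1nc(Nc2ccc(C(=O)N3CC4(COC4)C3)cc2OC)nc2[nH]ccc12` gives 1.1 mL.min-1.g-1. Compound 3 therefore stands within the scatter of both others, and the three values show no order.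

Compound 4 `CCOc1nc(Nc2ccc(C(=O)N3CCC4(CC3)CN(C)C4)cc2OC)nc2[nH]ccc12` differs from compound 3 at one place: a group of 10 heavy atoms (8 carbon, 2 nitrogen; one four-membered non-aromatic ring with 1 hetero atom, one six-membered non-aromatic ring with 1 hetero atom) in place of a group of 7 heavy atoms (5 carbon, 1 nitrogen, 1 oxygen; 2 four-membered non-aromatic rings with 1 hetero atom each), on a carbonyl carbon.

The measured steps all change the group on this same carbonyl carbon: a 1.9-fold higher number from compound 1 to compound 2 (0.27 log units; within the scatter), a 1.4-fold higher number from compound 1 to compound 3 (0.14 log units; within the scatter) and a 1.4-fold lower number from compound 2 to compound 3 (0.13 log units; within the scatter). All three stay within the scatter, so this assay has so far shown little response at this place. Each of those groups holds oxygen, however, while the entering group holds none and has a different ring set, so the measured steps cover it only loosely. A modest move towards a higher number is expected, with an uncertain size. The expected step is a 1.8-fold higher number from compound 3 to compound 4 (0.26 log units; within the scatter). For compound 4 the estimated value is 2 mL.min-1.g-1, with an expected range of 0.9 mL.min-1.g-1 to 5 mL.min-1.g-1.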

Compound 4, intrinsic clearance in microsomes: < 0.777 mL.min-1.g-1
Compound 4 gave a limit, no number (the forecaster's own chance of this, stated with the estimate: 3%); middle value at least 2.5-fold (0.41 log units) from the limit.
By their numbers in this assay, from the lowest: compounds 1, 3 and 2 (each within the scatter of the next). At a limit, below all of these: compound 4.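

In this assay, compound 4 alone among the compounds shown gives a limit and not a number: the limit of < 0.777 mL.min-1.g-1 in this assay, at which 1 of the 4 values shown sits.
The steps to it read as an at least 1.4-fold lower number from compound 3 to compound 4 (0.15 log units; that floor lies within the scatter), an at least 1.9-fold lower number from compound 2 to compound 4 (0.28 log units; that floor lies within the scatter) and an at least 1.0-fold lower number from compound 1 to compound 4 (0.01 log units; that floor lies within the scatter), so a group with no oxygen and with a different ring set, placed on this carbonyl carbon, brings no rise in this assay. All three floors lie within the scatter, so this place has still shown no response beyond the scatter, although the limit leaves the true size of each step unknown.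

From the compounds shown here alone, how far the true value of compound 4 lies from its limit stays open. Also open, going by these compounds, is whether an open-chain amine, such as a (2-dimethylaminoethyl)amino group, on the same carbonyl carbon would read the same way in this assay.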